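Halogen Swap on a Second Ketone Core

A few compounds are considered here, and "the series" means these few. Any claim that something is new, unique, unknown or untested is made for them only; others in the source may bear on it.

Measured compounds:
compound 1 `O=C1/C(=C/c2ccc(Cl)cc2)CCCc2ccccc21`: 9500 nM
compound 2 `O=C1/C(=C/c2ccc(Br)cc2)CCCc2ccccc21`: 18600 nM
compound 3 `O=C1CCCCC/C1=C\c1cccc(Cl)c1`: 25700 nM

These three compounds were tested in a functional assay on P388 cells (Mus musculus) for inhibition; a lower number here means a stronger inhibitor, a higher number a weaker inhibitor. Compound 2 differs from compound 1 by bromo in place of chloro on an aromatic carbon, and this change produced a 2.0-fold higher number from compound 1 to compound 2 (0.29 log units; within the scatter). Compound 3 sits on another core; how the core of compound 3 differs from that of compound 1 is not broken down here. Among the three numbers compound 3 stands highest, yet compared with compound 2 its value lies within the scatter, while the gap to compound 1 lies beyond it.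

Compound 4 `O=C1CCCCC/C1=C\c1cccc(Br)c1` has not yet been measured. It differs from compound 3 by bromo in place of chloro on an aromatic carbon. This is the same kind of change as that from compound 1 to compound 2, but not the same: in compound 1 the changed carbon is para to a large group, in compound 3 it is meta to a group of 9 heavy atoms. For the measured compounds named here, since the only guide is a single step on a different core, the expectation is loose. Compound 4 is expected to show a 1.6-fold higher number from compound 3 to compound 4 (0.19 log units; within the scatter), set beside a 2.0-fold higher number from compound 1 to compound 2 (0.29 log units; within the scatter), because a 2.0-fold higher number from compound 1 to compound 2 (0.29 log units; within the scatter) is the one comparable observation. Compound 4 is estimated at 40000 nM, with a range from 15000 nM to 110000 nM.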

Compound 4, half-maximal inhibitory concentration: 24100 nM
The estimate for compound 4 lay 1.7-fold (0.22 log units) above the measured number; the range from low to high includes it.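

In this assay, bromo in place of chloro on an aromatic carbon gave a 1.1-fold lower number from compound 3 to compound 4 (0.03 log units; within the scatter), so compound 3 and compound 4 cannot be told apart on this read-out. Set beside the same change on the core of compound 1, this step shows no measurable dependence on the core: the same change on two cores in this assay, a 2.0-fold higher number (0.29 log units; within the scatter) from compound 1 to compound 2 and a 1.1-fold lower number (0.03 log units; within the scatter) from compound 3 to compound 4, 2.1-fold (0.32 log units) apart, within the scatter of two such steps This shows only that, across these two pairs, the swap stays within the scatter on both cores and that the two steps do not separate; it does not show that the two halogens are interchangeable in general, since each core contributes a single step and the changed carbon in compound 4 is meta to a group of 9 heavy atoms, which does not hold for the changed carbon in compound 2.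

The compounds shown leave open how either core would respond if the halogen gave way to a different kind of group, such as a methoxy group, an amine or a carboxylic acid. They also leave open whether the chloro-to-bromo swap would behave the same way on any further core.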